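The source may report more compounds than this note shows. Statements on the series, on what has been measured and on what is new or still open speak of the compounds shown alone.

Compounds measured so far:
Compound 1, `CC(C)=C1C[C@]2(O)[C@@H](CC[C@@H]2C)[C@@](C)(O)CC1=O`, gives 92400 nM.
Compound 2, `CC(=O)C(C[C@@H]1[C@H](C(C)=O)CC[C@]1(C)O)=C(C)C`, gives 78700 nM.
Compound 3, `CC1=C2C[C@H]3[C@@](C)(O)CC[C@@]34O[C@@]2(C[C@]4(C)O)OC1=O`, gives 7600 nM.

These three compounds were tested in a functional assay on RAW264.7 cells (Mus musculus) for inhibition, read by Griess assay; a lower number here means a stronger inhibitor, a higher number a weaker inhibitor. Among them compound 3 holds the lowest number of the three: the nearest of the others is compound 2, whose number is higher by a gap that lies beyond the scatter, and the furthest is compound 1, higher again by a gap that also lies beyond the scatter. Compound 3 is therefore the strongest inhibitor of the three in this assay.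

The account now turns from compound 3 to compound 4, `CC1=C2C[C@H]3[C@@](C)(O)CC[C@@]34O[C@@]2(C[C@@]4(C)O)OC1=O`. The difference between them is small on paper: the two compounds have the same atoms and bonds and differ only in configuration as drawn: 1 of 5 stereo elements differ; a stereocentre at a saturated ring carbon is drawn S in compound 3 and R in compound 4. Compound 4 is thus an epimer of compound 3 at one saturated ring carbon, with nothing added and nothing removed.

Among the measured compounds shown here, no measured pair among the three compounds shows what such a change of configuration alone does in this assay, so the data give no direction to lean on. In the absence of such a reference, the expectation for compound 4 is a step from compound 3 that is more likely than not within the scatter, with a wide allowance either way; the expected step is a 1.3-fold higher number from compound 3 to compound 4 (0.12 log units; within the scatter). Compound 4 is accordingly estimated at 10000 nM, in a range from 3000 nM to 40000 nM.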

Compound 4, half-maximal inhibitory concentration: 8500 nM
Compound 4: the middle estimate sits 1.2-fold (0.07 log units) above what was measured, within the range that was stated.
By their numbers in this assay, from the lowest: compounds 3 and 4 (each within the scatter of the next); then compounds 2 and 1 (each within the scatter of the next).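

In this assay, among the compounds shown here, the change of configuration at this saturated ring carbon comes to a 1.1-fold higher number from compound 3 to compound 4 (0.05 log units; within the scatter), the first step that can be read at a single place. At this stereocentre, then, the S and R drawings cannot be told apart in this assay, so the configuration here is not shown to matter for inhibition on this core, at least for this one pair. The comparison is a clean one, with nothing entering or leaving the structure, so no other change has to be weighed against it: the fact that compounds 3 and 4 differ only in the configuration as drawn.

The compounds shown say only what inverting this one stereocentre does, and leave open whether the other stereo elements of the shared core are equally free to change. They also leave open how the number would respond to a change of substituent on this saturated ring carbon, such as an amine or a carboxylic acid, since a step in configuration says nothing about a step in the group itself.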